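From Amide to Imine on a Shared Core

This account rests on a few compounds, and the source may have more. Where it says the series, first, only, none or still open, it means among the compounds named here.

Compound 1 `N#CC1=C(NC(=O)/C=C/c2ccccc2)N(c2ccc(S(N)(=O)=O)cc2)C2=C(C(=O)CCC2)C1c1ccc(Cl)cc1Cl`: 40%
Compound 2 `COc1cc(C(=O)NC2=C(C#N)C(c3ccc(Cl)cc3Cl)C3=C(CCCC3=O)N2c2ccc(S(N)(=O)=O)cc2)cc(OC)c1OC`: 95%
Compound 3 `NC1=C(C(=O)O)C(c2ccc(Cl)cc2Cl)C2=C(CCCC2=O)N1c1ccc(S(N)(=O)=O)cc1`: 10%

All three were tested in a functional assay on Ehrlich cells (Mus musculus) for cytotoxicity, read by trypan blue exclusion, with a stated time of 2 h, tested at 50 ug/mL; on this read-out lower numbers stand for a weaker effect and higher numbers for a stronger effect at the one concentration tested. Compound 1 stands second highest of the three numbers, with compound 3 lower and compound 2 higher, both beyond the scatter. For the measured compounds named here, the only measured step, a number 55 percentage points higher from compound 1 to compound 2 (beyond the scatter), puts 3,4,5-trimethoxyphenyl in place of 2-phenylethenyl on a carbonyl carbon while keeping the amide itself. Compound 4 `CCO/C=N/C1=C(C#N)C(c2ccc(Cl)cc2Cl)C2=C(CCCC2=O)N1c1ccc(S(N)(=O)=O)cc1` changes something else: a group of 5 heavy atoms (3 carbon, 1 nitrogen, 1 oxygen; no ring) in place of a group of 11 heavy atoms (9 carbon, 1 nitrogen, 1 oxygen; one six-membered aromatic ring of carbon only), on a double-bonded ring carbon. No measured step covers a change of this kind, so nothing shown tells the direction, and any estimate is wide. Compound 4 is expected to give 30%, between 10% and 60%. That estimate means an expected step of a number 10 percentage points lower from compound 1 to compound 4 (within the scatter), which may fall within the scatter.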

Compound 4, a percentage reported as activity, at one concentration (the size of the read-out at that concentration, not a potency): 35%
For compound 4 the middle estimate is 5 percentage points below the measured one, within the range that was stated.
By their numbers in this assay, from the lowest: compound 3; then compounds 4 and 1 (each within the scatter of the next); then compound 2.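

In this assay, replacing the ((2-phenylethenyl)carbonyl)amino group on the double-bonded ring carbon with the smaller, ring-free ethoxy imine gives a number 5 percentage points lower from compound 1 to compound 4 (within the scatter). At this position, then, neither the amide nor the aromatic ring of that group is required for a reading at this level, something the amide-to-amide step could not show. Nothing shown explains why the two numbers stay so close. Still open, as far as these compounds go, is whether a longer chain, such as butoxy in place of ethoxy, would change the number, and how a plain benzoyl amide would compare.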